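A few compounds are considered here, and "the series" means these few. Any claim that something is new, unique, unknown or untested is made for them only; others in the source may bear on it.

Of the compounds shown here, three have been measured in a functional assay on the whole organism (Tail, strain ICR) with Mus musculus as the target, in the tail flick test, with a stated time of 90 min, at a dose of 25 umol/kg by the oral route; a lower number here means a weaker effect, a higher number a stronger effect of the compound at the dose given. Compound 1, `O=C(CN(c1ncnc2c1ncn2C1CCCCO1)C1CC1)N[C@@H](CO)C(=O)OCc1ccccc1`, gives 32.2%. Compound 2, `C[C@@H](O)[C@H](NC(=O)CN(c1nc(Cl)nc2[nH]cnc12)C1CC1)C(=O)O`, gives 35.9%. Compound 3, `O=C(O)CC[C@H](NC(=O)CN(c1nc(Cl)nc2[nH]cnc12)C1CC1)C(=O)O`, gives 44.7%, the largest of the three numbers on paper; compound 2 sits within the scatter of it, and only compound 1 lies beyond the scatter. Going by the values given here, the one step measured so far between two compounds that differ in a single place is a number 8.8 percentage points higher from compound 2 to compound 3 (within the scatter), a change on the side chain of the same core.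

Compound 4, `NC(=O)CC[C@H](NC(=O)CN(c1nc(Cl)nc2[nH]cnc12)C1CC1)C(=O)O`, differs from compound 3 by amino in place of hydroxy on a carbonyl carbon. Among the compounds with values here, no measured step alters a carbonyl carbon in this way, so the only guidance is the side-chain step from compound 2 to compound 3, which stayed within the scatter. A step within the scatter is therefore expected here too, with no direction claimed. For compound 4 the expected reading in this assay is 42%, between 30% and 55%, which means an expected step of a number 2.7 percentage points lower from compound 3 to compound 4 (within the scatter).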

Compound 4, a percentage reported as activity, at one dose (the size of the read-out at that dose, not a potency): 41.1%
The estimate for compound 4 lay 0.9 percentage points above the measured number; low and high end bracket the measured number.
By their numbers in this assay, from the lowest: compounds 1, 2, 4 and 3 (each within the scatter of the next, the first and the last beyond it).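

In this assay, amino in place of hydroxy on a carbonyl carbon gives a number 3.6 percentage points lower from compound 3 to compound 4 (within the scatter), so 2-carbamoylethyl can stand in for 2-carboxyethyl on this core without a step beyond the scatter, and a free carboxy group at the end of this side chain is not shown to be required for the read-out at this dose. Going by these compounds alone, the earlier compounds offered only the step from 1-hydroxyethyl to 2-carboxyethyl; the new side chain adds a number 5.2 percentage points higher from compound 2 to compound 4 (within the scatter), so all three side chains on the shared core lie within the scatter of one another. No measurement at hand bears on why these side chains read alike.

Going by these compounds, whether an amine at the end of this side chain, or a longer chain ending in a carboxylic acid, would also stay within the scatter remains open. So does whether the 2-carbamoylethyl and 2-carboxyethyl compounds would separate at another dose or time.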